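Methoxy in place of fluoro on a triazole-linked chromone

The compounds below may be only part of what the source reports. "The series", "measured", "known", "first", "only" and "open" are said of these compounds alone.

Compound 1 `O=c1ccoc2cc(OCc3cn(Cc4ccc(F)cc4)nn3)ccc12`: in a functional assay on HeLa cells (Homo sapiens) for cytotoxicity, read by MTT assay, with a stated time of 48 h (a lower number here means a stronger inhibitor, a higher number a weaker inhibitor), compound 1 gives 12000 nM.
Compound 2 `O=c1ccoc2cc(OCc3cn(Cc4ccc([N+](=O)[O-])cc4)nn3)ccc12`: compound 2 gives 25700 nM.
Compound 3 `C#CCOc1ccc2c(=O)ccoc2c1`: compound 3 gives 64700 nM.

Compound 1 stands lowest of the three numbers in this assay. The nearest is compound 2, reached by a 2.1-fold higher number from compound 1 to compound 2 (0.33 log units; beyond the scatter). The furthest is compound 3, which lacks the triazole arm altogether and gives the highest number of the set.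

Compound 4 `COc1ccc(Cn2cc(COc3ccc4c(=O)ccoc4c3)nn2)cc1` differs from compound 1 in one place: methoxy in place of fluoro on an aromatic carbon. Going by the values given here, the only measured step that bears on this position is the one from compound 1 to compound 2, where a different group replaced the same fluoro and produced a modest rise, a 2.1-fold higher number from compound 1 to compound 2 (0.33 log units; beyond the scatter). Among the compounds with values here, no measured pair shows a methoxy at this position, so the expectation rests on that single step alone. The exchange of fluoro for methoxy is therefore expected to move the number little, if at all, beyond the scatter, and in the same upward direction if anywhere.

Compound 4 is thus estimated to give 15000 nM in this assay, within a range of 6000 nM to 40000 nM. This estimate means a step of a 1.3-fold higher number from compound 1 to compound 4 (0.10 log units; within the scatter).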

Compound 4, half-maximal inhibitory concentration: 14400 nM
The estimate for compound 4 lay 1.0-fold (0.02 log units) above the measured number; measured number inside the range.
By their numbers in this assay, from the lowest: compounds 1, 4 and 2 (each within the scatter of the next, the first and the last beyond it); then compound 3.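

In this assay, the change from 4-fluorobenzyl to 4-methoxybenzyl gave a 1.2-fold higher number from compound 1 to compound 4 (0.08 log units; within the scatter), so this position accepted methoxy, with one more heavy atom and a hydrogen-bond acceptor, without a shift that can be told from the scatter. Set against the nitro group, methoxy gave a 1.8-fold lower number from compound 2 to compound 4 (0.25 log units; within the scatter), so compound 4 cannot be separated from either of its two neighbours at this position, even though those two lie beyond the scatter of each other. No measurement accompanies these numbers that could account for them.

With only fluoro, nitro and methoxy at this position, the numbers give no ranking of groups. As far as these compounds go, whether an amine, a carboxylic acid or a longer chain such as butoxy would stay within this narrow band remains open.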